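Swapping fluoro for methyl on the aromatic ring

This account rests on a few compounds, and the source may have more. Where it says the series, first, only, none or still open, it means among the compounds named here.

Compound 1 `O/N=C(/CCN1CCN(c2ccccn2)CC1)c1ccccc1` gives 74% in a functional assay on HEK293 cells with D(4) dopamine receptor (Homo sapiens) as the target, read by FLIPR; a lower number here means a smaller maximal response, a higher number a larger maximal response. Compound 2 `Cc1ccccc1/C(CCN1CCN(c2ccccn2)CC1)=N/O` gives 82%. Compound 3 `O/N=C(\CCN1CCN(c2ccccn2)CC1)c1cccc(F)c1` gives 72%.

Among the compounds with values here, compound 3 is not separated from compound 1 or compound 2 by more than the scatter; the step of a number 10 percentage points lower from compound 2 to compound 3 (within the scatter) is the only measured step, and it stays within the scatter. Compound 4 `Cc1cccc(/C(CCN2CCN(c3ccccn3)CC2)=N/O)c1` differs from compound 3 as follows: methyl in place of fluoro on an aromatic carbon. The change sits on an aromatic carbon of a six-membered aromatic ring of carbon only, meta to a large group. The measured step covers a different position and a different group, so it gives only a weak lead. No step beyond the scatter is expected: compound 4 is estimated at 75%, between 62% and 88%, a step of a number 3 percentage points higher from compound 3 to compound 4 (within the scatter).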

Compound 4, largest response reached (reported as efficacy), in percent of the reference or control that the assay uses: 74%
Beside the measured number, compound 4's estimate is 1 percentage points above it; the measured number falls inside the stated range.
By their numbers in this assay, from the lowest: compounds 3, 1, 4 and 2 (each within the scatter of the next).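

In this assay, methyl in place of fluoro on this aromatic carbon gives a number 2 percentage points higher from compound 3 to compound 4 (within the scatter), so at this position the two groups cannot be told apart by maximal response. The change to 3-methylphenyl from 2-methylphenyl gives a number 8 percentage points lower from compound 2 to compound 4 (within the scatter), so the place of the methyl on the ring cannot be told from these numbers either. Nothing available explains these results.

As far as these compounds go, whether an amine or a carboxylic acid on this aromatic carbon would move the response beyond the scatter remains open.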